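Chain lengthening on two related ketone cores

A few compounds are considered here, and "the series" means these few. Any claim that something is new, unique, unknown or untested is made for them only; others in the source may bear on it.

Compound 1 `C#CCN(C)CCCCCOc1ccc2c(c1)CCCC2=O` and compound 2 `C#CCN(C)CCCCCCOc1ccc2c(c1)CCCC2=O` share one core. In an assay on BTI cells for inhibition of Amine oxidase [flavin-containing] B (Homo sapiens), read by fluorescence and Amplex Red, with a stated time of 15 min (on this read-out higher numbers stand for weaker inhibition and lower numbers for stronger inhibition), compound 1 gives 46.3 nM, and compound 2 gives 133 nM. The change between them, ((methyl(propargyl)amino)methyl in place of methyl(propargyl)amino on a saturated chain carbon, five bonds along the chain from an oxygen on an aromatic ring), produced a 2.9-fold higher number from compound 1 to compound 2 (0.46 log units; beyond the scatter). Compound 3 `C#CCN(C)CCCCCOc1ccc2c(c1)OCCC2=O` has a different core; how the two cores differ is not broken down here. In this assay compound 3 gives 4 nM, the lowest of the three measured numbers. Compound 4 `C#CCN(C)CCCCCCOc1ccc2c(c1)OCCC2=O` is related to compound 3 by the same change, ((methyl(propargyl)amino)methyl in place of methyl(propargyl)amino on a saturated chain carbon, five bonds along the chain from an oxygen on an aromatic ring), and has not yet been measured. Because compound 1 to compound 2 showed a 2.9-fold higher number from compound 1 to compound 2 (0.46 log units; beyond the scatter), compound 4 is expected to show a 3.0-fold higher number from compound 3 to compound 4 (0.48 log units; beyond the scatter). The estimate for compound 4 in this assay is therefore 12 nM, expected to lie between 5 nM and 30 nM.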

Compound 4, half-maximal inhibitory concentration: 117 nM
Compound 4: the middle estimate sits 9.8-fold (0.99 log units) below what was measured; the whole stated range lies below it.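

In this assay the same change, (methyl(propargyl)amino)methyl in place of methyl(propargyl)amino, gave a far larger step on the core of compound 3 (a 29-fold higher number from compound 3 to compound 4 (1.47 log units; beyond the scatter)) than on the core of compound 1. The direction of the step carried over between these two cores, but its size did not, so a step read on one core could not be taken over unchanged to the other. This rests on a single pair of steps and does not show which difference between the cores is responsible: the same change on two cores in this assay, a 2.9-fold higher number (0.46 log units; beyond the scatter) from compound 1 to compound 2 and a 29-fold higher number (1.47 log units; beyond the scatter) from compound 3 to compound 4, 10-fold (1.01 log units) apart, beyond the scatter of two such steps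

The compounds shown leave open how a shorter chain or a still longer chain would behave on each core. They also leave open whether the gap between the cores would persist with an ethyl group in place of the methyl on the amine.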